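Removing the aryl cap from the alkyne of compound 3

The source may hold more compounds than are shown below. What is called first, only, known or untested is meant among the compounds shown, and "the series" means these compounds.

Three compounds sharing one core were measured in an assay on CHO cells for displacement of a labelled ligand from adenosine receptor A3 (Homo sapiens); on this read-out lower numbers stand for stronger inhibition and higher numbers for weaker inhibition. Compound 1 `CONc1nc(C#CCCCC#N)nc2c1ncn2[C@@H]1O[C@H](CO)[C@@H](O)[C@H]1O` gives 4.1 nM; compound 2 `CONc1nc(C#CC2CCCCC2O)nc2c1ncn2[C@@H]1O[C@H](CO)[C@@H](O)[C@H]1O` gives 1.7 nM; compound 3 `CONc1nc(C#Cc2cccc(C(F)(F)F)c2)nc2c1ncn2[C@@H]1O[C@H](CO)[C@@H](O)[C@H]1O` gives 23 nM. Compound 3 therefore has the highest number of the three, standing a 5.6-fold higher number from compound 1 to compound 3 (0.75 log units; beyond the scatter) and a 14-fold higher number from compound 2 to compound 3 (1.13 log units; beyond the scatter), so within this small set the aryl substituent on the triple-bonded carbon is weaker than either of the non-aromatic substituents, with the cyclohexyl variant showing a 2.4-fold lower number from compound 1 to compound 2 (0.38 log units; beyond the scatter).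

Compound 4 `C#Cc1nc(NOC)c2ncn([C@@H]3O[C@H](CO)[C@@H](O)[C@H]3O)c2n1` is not yet measured. It differs from compound 3 by a single change: hydrogen in place of 3-(trifluoromethyl)phenyl on a triple-bonded carbon. The two steps that bear on this are those leading into compound 3, which show that replacing a non-aromatic substituent by the trifluoromethylphenyl group raised the number by a modest to large amount. For the measured compounds named here, compound 4 goes further than either comparator, leaving nothing but hydrogen on the triple-bonded carbon, and no measured pair tests that exact case. On the strength of the two steps into compound 3 a return toward lower numbers is expected, but tempered by the absence of any substituent, so the expected step is a 2.3-fold lower number from compound 3 to compound 4 (0.36 log units; beyond the scatter). Compound 4 is accordingly estimated at 10 nM in this assay, within a range from 3 nM to 35 nM.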

Compound 4, inhibition constant: 23 nM
Compound 4: middle estimate off by 2.3-fold (0.36 log units), on the low side, and the stated range covers the measured number.
By their numbers in this assay, from the lowest: compound 2; then compound 1; then compounds 3 and 4 (each within the scatter of the next).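

In this assay, hydrogen in place of 3-(trifluoromethyl)phenyl on the triple-bonded carbon gives no change at the digits printed from compound 3 to compound 4 (within the scatter), so the loss of this whole aromatic group does not register at this position. The same bare alkyne sets the two non-aromatic substituents apart from hydrogen: replacing 2-hydroxycyclohexyl gives a 14-fold higher number from compound 2 to compound 4 (1.13 log units; beyond the scatter), and replacing 3-cyanopropyl gives a 5.6-fold higher number from compound 1 to compound 4 (0.75 log units; beyond the scatter). Compound 3 alone could be read as an aryl group raising the number, but against hydrogen as the baseline, the set shows instead that the lower numbers belong to compound 1 and compound 2, while compound 3 and compound 4 sit level. Nothing given here explains these steps.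

The compounds shown leave open whether a plain cyclohexyl ring without the hydroxyl, or a butyl chain without the nitrile, would keep the lower numbers of compound 2 and compound 1. They also leave open whether an unsubstituted phenyl, or a phenyl carrying an amine or a carboxylic acid, would stay level with compound 3 and compound 4 or move away from them.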